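Swapping phenyl for isopropyl in an antiproliferative series

The source may report more compounds than this note shows. Statements on the series, on what has been measured and on what is new or still open speak of the compounds shown alone.

Of the compounds shown here, three have been tested in a functional assay on L1210 cells (Mus musculus) for antiproliferative activity; on this read-out higher numbers stand for higher potency (the scale is a negative logarithm) and lower numbers for lower potency. Compound 1 `CN(C)/N=N/c1nc(Cc2ccccc2)[nH]c1C(N)=O` gives 2.89. Compound 2 `CN(/N=N/c1ccc(C(N)=O)cc1)c1cccs1` gives 2.9, and compound 3 `CCCCCCCCN(C)/N=N/c1nc[nH]c1C(N)=O` gives 3. Compound 1 has the lowest of the three numbers, but both gaps, to compound 2 and to compound 3, lie within the usual scatter, so the three cannot be told apart on this read-out.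

Compound 4 `CC(C)Cc1nc(/N=N/N(C)C)c(C(N)=O)[nH]1` has not yet been measured. It differs from compound 1 in one place: isopropyl in place of phenyl on a saturated chain carbon bound to an aromatic carbon. Going by the values given here, no pair of measured compounds differing in one place is available to show how such a change moves the numbers, so there is no direct guide. Among the compounds with values here, the three measured compounds, though varied in structure, all fall close together in this assay, and that closeness is the only basis for expecting compound 4 to land near compound 1.

For compound 4 in this assay the estimate is 2.9, with a range from 2.4 to 3.4. The step this estimate means, a number 0.01 log units higher from compound 1 to compound 4 (within the scatter), is expected to stay within the scatter, with no clear direction.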

Compound 4, logarithm of the reciprocal of the active concentration, log(1/C): 3.53
Compound 4: middle estimate off by 0.63 log units, on the low side; measured number outside the range, above it.
By their numbers in this assay, from the lowest: compounds 1, 2 and 3 (each within the scatter of the next); then compound 4.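

In this assay, going by these compounds alone, this position proves able to move the number: isopropyl in place of phenyl on a saturated chain carbon bound to an aromatic carbon gives a number 0.64 log units higher from compound 1 to compound 4 (beyond the scatter), the only step here and one beyond the scatter. Phenyl has 6 heavy atoms and an aromatic ring while isopropyl has 3 heavy atoms and no ring, and neither has hydrogen-bond donors or acceptors or a net charge. Nothing at hand explains why the number rises.

This single step cannot separate the loss of the phenyl ring from the arrival of the isopropyl group. A methyl group, a longer chain, a cyclohexyl ring or an amine at this place would be needed to show how far the trend extends.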